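The source may report more compounds than this note shows. Statements on the series, on what has been measured and on what is new or still open speak of the compounds shown alone.

Of the compounds shown here, three have been measured so far in a functional assay on MDA-MB-435 cells (Homo sapiens) for inhibition; a higher number here means a weaker inhibitor of growth, a lower number a stronger inhibitor of growth. There, compound 1 `COc1cc(/C=C/c2ccc(S(N)(=O)=O)cc2)cc(OC)c1` gives 18700 nM. Compound 3 `COc1cccc(/C=C/c2ccc(S(N)(=O)=O)cc2)c1` gives 17400 nM. Compound 2 `NS(=O)(=O)c1ccc(/C=C/c2ccc(O)c(O)c2)cc1` gives 16800 nM, which places it level with the other two, as its gaps to both lie within the scatter.

The step of interest leads from compound 2 to compound 4 `NS(=O)(=O)c1ccc(/C=C/c2ccc(O)cc2)cc1`, which has no number yet. The change is hydrogen in place of hydroxy on an aromatic carbon, ortho to a hydroxy group, so that one hydroxy group of compound 2 remains in compound 4.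

Within the data shown here, only one measured step bears on this change, and it does so indirectly. It is a 1.1-fold lower number from compound 1 to compound 3 (0.03 log units; within the scatter), and it puts hydrogen in place of methoxy, not hydroxy, on an aromatic carbon. That step stays within the scatter. Among the measured compounds shown here, no measured pair shows the loss of a hydroxy group itself, so the evidence is thin. Even so, all three measured compounds, with their different groups, lie within the scatter of one another, and no step beyond the scatter is expected in this assay, in either direction. The estimated step is a 1.0-fold higher number from compound 2 to compound 4 (0.01 log units; within the scatter). Compound 4 is expected at about 17000 nM, with an estimated range of 8000 nM to 32000 nM.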

Compound 4, concentration for 50% growth inhibition: 20300 nM
Estimate against measurement, compound 4: 1.2-fold (0.08 log units) below, and the stated range covers the measured number.
By their numbers in this assay, from the lowest: compounds 2, 3, 1 and 4 (each within the scatter of the next).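

In this assay, among these compounds, the loss of a hydroxy group can now be read directly, where the earlier compounds offered only hydrogen in place of methoxy: the change gives a 1.2-fold higher number from compound 2 to compound 4 (0.08 log units; within the scatter) and so leaves the two compounds level. At this position, ortho to a hydroxy group and meta to a large group, the second hydroxy group of compound 2 therefore makes no difference that can be told from the scatter, as long as the other hydroxy group stays in place. No measurement shown here explains this lack of effect, or says whether the two compounds behave alike in the cells for the same reason.

What the compounds shown leave open is the role of the hydroxy group that compound 4 keeps, since the effect of replacing it with hydrogen, an amine or a carboxylic acid cannot be read from them. On these data alone, it also remains open whether a larger group at the position studied here, such as a longer chain or a bromine atom, would move the number beyond the scatter in this assay at all.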